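The source may report more compounds than this note shows. Statements on the series, on what has been measured and on what is new or still open speak of the compounds shown alone.

The compounds here share one core and differ only in the aromatic group attached to a carbonyl carbon. Compound 1 `COc1cc(C(=O)C2Sc3nnc(-c4cc(OC)c(OC)c(OC)c4)n3NC2c2ccco2)cc(OC)c1OC` carries a 3,4,5-trimethoxyphenyl group there. In a functional assay on HepG2 cells (Homo sapiens) for cytotoxicity, read by MTT assay, with a stated time of 48 h (on this read-out lower numbers stand for stronger inhibition and higher numbers for weaker inhibition), compound 1 reaches only the limit of the assay, > 100000 nM, so its true value is not known as a number. Compound 2 `COc1cc(-c2nnc3n2NC(c2ccco2)C(C(=O)c2ccc(C)cc2)S3)cc(OC)c1OC` bears a 4-methylphenyl group in the same place and gives 17400 nM in this assay. Compound 3 `COc1cc(-c2nnc3n2NC(c2ccco2)C(C(=O)c2ccc([N+](=O)[O-])cc2)S3)cc(OC)c1OC` bears a 4-nitrophenyl group and gives 87800 nM in this assay.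

Two measured steps start from compound 1: an at least 5.7-fold lower number from compound 1 to compound 2 (0.75 log units; beyond the scatter), and an at least 1.1-fold lower number from compound 1 to compound 3 (0.05 log units; that floor lies within the scatter). Both point the same way, but because compound 1 sits at the limit (the limit of > 100000 nM in this assay, at which 1 of the 3 values shown sits), each of them is only a floor, not a measured size. The step of a 5.0-fold higher number from compound 2 to compound 3 (0.70 log units; beyond the scatter) shows that the group on the carbonyl carbon can move the number by a modest amount.

The unmeasured compound 4 `COc1cc(-c2nnc3n2NC(c2ccco2)C(C(=O)c2ccco2)S3)cc(OC)c1OC` differs from compound 1 by furan-2-yl in place of 3,4,5-trimethoxyphenyl on a carbonyl carbon. Given that both measured steps from compound 1 go toward lower numbers, a modest step in that direction is expected, an at least 2.5-fold lower number from compound 1 to compound 4 (0.39 log units; beyond the scatter). In this assay compound 4 is therefore estimated to give about 40000 nM, with a range from 10000 nM to 150000 nM.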

Compound 4, half-maximal inhibitory concentration: > 100000 nM
Compound 4 gave a limit, no number; the forecaster's own chance of this, stated with the estimate: 30%; middle value at least 2.5-fold (0.39 log units) from the limit.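

Compound 4 shows that a five-membered furan-2-yl ring on this carbonyl carbon, like the larger 3,4,5-trimethoxyphenyl group, leaves this assay at its limit rather than giving a number, so that limit is now reached by two different groups: the limit of > 100000 nM in this assay, at which 2 of the 4 values shown sit. Replacing 4-methylphenyl with furan-2-yl gives an at least 5.7-fold higher number from compound 2 to compound 4 (0.75 log units; beyond the scatter), which makes compound 2 the most potent of the four compounds, since its steps to all the others lie beyond the scatter, and shows that an aromatic ring at this position is not enough on its own for a measurable effect at the level of compound 2. Replacing 4-nitrophenyl with furan-2-yl gives an at least 1.1-fold higher number from compound 3 to compound 4 (0.05 log units; that floor lies within the scatter), which is only a floor, and the step between compound 1 and compound 4 cannot be read, as both values are limits.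

Going by these compounds, the true values of compound 1 and compound 4 remain unknown, so these two groups cannot be ranked against each other. The compounds shown also leave open how a plain phenyl, or a phenyl ring carrying an amine or a carboxylic acid, would behave at this position, and whether a non-aromatic group such as cyclohexyl would give a number at all.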